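The source may hold more compounds than are shown below. What is called first, only, known or untested is meant among the compounds shown, and "the series" means these compounds.

Measured so far in a functional assay on MDA-MB-231 cells (Homo sapiens) for cytotoxicity, read by MTT assay, with a stated time of 48 h; on this read-out higher numbers stand for weaker inhibition and lower numbers for stronger inhibition:
- compound 1 `COc1cc(/C=C/c2ccc(OCCCCC(=O)NO)cc2)cc(OC)c1`: 4210 nM
- compound 2 `COc1cc(/C=C/c2ccc(OCc3ccccc3C(=O)NO)cc2)cc(OC)c1`: 7180 nM
- compound 3 `COc1cc(/C=C/c2ccc(NCc3ccc(/C=C/C(=O)NO)cc3)cc2)cc(OC)c1`: 5950 nM

The three values lie within the scatter of one another, so compound 1 at 4210 nM does not separate from compound 2 or compound 3 on these numbers.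

The next compound to be read is compound 4 `COc1cc(/C=C/c2ccc(OCCc3cn(CC(=O)NO)nn3)cc2)cc(OC)c1`. Its difference from compound 1 is 1-((hydroxycarbamoyl)methyl)-1H-1,2,3-triazol-4-yl in place of 2-(hydroxycarbamoyl)ethyl on a saturated chain carbon, two bonds along the chain from an oxygen on an aromatic ring. The entering group brings one five-membered aromatic ring with 3 hetero atoms, on a saturated chain carbon, two bonds along the chain from an oxygen on an aromatic ring.

Among the measured compounds shown here, only one measured step changes the group carrying the hydroxycarbamoyl end while leaving the core of compound 1 in place: a 1.7-fold higher number from compound 1 to compound 2 (0.23 log units; within the scatter). That step also brings in a ring, and it stays within the scatter. Compound 3 differs from compound 1 in more than one place, so it offers only its value as a general guide. For the measured compounds named here, no measured compound carries the triazolyl group.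

On this limited evidence, no step beyond the scatter is expected in this assay, with at most a slight drift towards higher numbers. The expected step is a 1.4-fold higher number from compound 1 to compound 4 (0.15 log units; within the scatter). For compound 4 the estimated value is 6000 nM, with an expected range from 2500 nM to 14000 nM.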

Compound 4, half-maximal inhibitory concentration: 6520 nM
Beside the measured number, compound 4's estimate is 1.1-fold (0.04 log units) below it; low and high end bracket the measured number.
By their numbers in this assay, from the lowest: compounds 1, 3, 4 and 2 (each within the scatter of the next).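

In this assay, the change to 1-((hydroxycarbamoyl)methyl)-1H-1,2,3-triazol-4-yl gives a 1.5-fold higher number from compound 1 to compound 4 (0.19 log units; within the scatter), so a five-membered aromatic ring with 3 hetero atoms can enter on a saturated chain carbon, two bonds along the chain from an oxygen on an aromatic ring, without a step beyond the scatter. Together with a 1.7-fold higher number from compound 1 to compound 2 (0.23 log units; within the scatter), this gives two single-place changes to the group carrying the hydroxycarbamoyl end, each bringing in a ring, and neither separates from compound 1; the entering group in compound 4 also has 10 heavy atoms against 6 in the group it replaces. Nothing measured here bears on why the read-out holds across this change.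

Since no step shown leaves the scatter in this assay, it remains open whether the group at this place influences the read-out at all. Also open, going by these compounds, is whether a longer chain between the triazolyl ring and the hydroxycarbamoyl end, or a carboxylic acid or an amine in place of that end, would give a step beyond the scatter.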